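This account rests on a few compounds, and the source may have more. Where it says the series, first, only, none or still open, it means among the compounds named here.

Among the measured compounds shown here, compound 3, `COc1ccc(Cn2c(=O)n(C3OC(CO)[C@@H](O)[C@H]3O)c3nc(N)nc(O)c32)cc1`, gives the smallest maximal response of the three compounds measured so far in a functional assay on the whole organism (B cells) with Mus musculus as the target; on this read-out higher numbers stand for larger maximal responses and lower numbers for smaller maximal responses: compound 3 gives 44%. Compound 1, `[N-]=[N+]=NCC(O)Cn1c(=O)n(C2OC(CO)[C@@H](O)[C@H]2O)c2nc(N)nc(O)c21`, gives 91% in this assay, and compound 2, `Nc1nc(O)c2c(n1)n(C1OC(CO)[C@@H](O)[C@H]1O)c(=O)n2CC(O)CO`, gives 136% in this assay. Both steps that lead to compound 3 were large falls: a number 47 percentage points lower from compound 1 to compound 3 (beyond the scatter) and a number 92 percentage points lower from compound 2 to compound 3 (beyond the scatter). In both, a chain carrying oxygen or nitrogen groups on the saturated chain carbon bound to the aromatic nitrogen was exchanged for 4-methoxyphenyl, and the maximal response dropped well beyond the scatter.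

Compound 4, `CN(C)CCCn1c(=O)n(C2OC(CO)[C@@H](O)[C@H]2O)c2nc(N)nc(O)c21`, reverses this kind of change: 2-(dimethylamino)ethyl in place of 4-methoxyphenyl on a saturated chain carbon bound to an aromatic nitrogen. The 4-methoxyphenyl leaves and a chain with a single acceptor enters, so the two steps into compound 3 bear directly on this one, though in the opposite direction. For the measured compounds named here, neither of those steps involved a dimethylamino chain, and no step in this set shows what such a chain does on its own, so the size of the recovery is uncertain. Compound 4 is therefore expected to rise in this assay by roughly a number 46 percentage points higher from compound 3 to compound 4 (beyond the scatter), bringing it back toward the level of compound 1. The estimate for compound 4 in this assay is 90%, with a range from 55% to 130%.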

Compound 4, largest response reached (reported as maximal response), in percent of the reference or control that the assay uses: 83%
The estimate for compound 4 lay 7 percentage points above the measured number; the range from low to high includes it.
By their numbers in this assay, from the lowest: compound 3; then compounds 4 and 1 (each within the scatter of the next); then compound 2.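

In this assay, the exchange of 4-methoxyphenyl for 2-(dimethylamino)ethyl gives a number 39 percentage points higher from compound 3 to compound 4 (beyond the scatter), which shows that a large response at this position does not depend on a hydroxy or azido group on the chain; the two groups have the same counts of hydrogen-bond donors and acceptors, so those counts do not separate compound 3 from compound 4. The change from 2-azido-1-hydroxyethyl to 2-(dimethylamino)ethyl gives a number 8 percentage points lower from compound 1 to compound 4 (within the scatter), whereas the change from 1,2-dihydroxyethyl to 2-(dimethylamino)ethyl gives a number 53 percentage points lower from compound 2 to compound 4 (beyond the scatter), leaving compound 2 with the largest response of the four and compound 3 with the smallest. No measurement shown here explains these differences in response.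

The compounds leave open whether the low value of compound 3 follows from the phenyl ring or from its methoxy group, a question that a plain benzyl group or a 4-hydroxybenzyl group at this position would address. They also leave open how far the response depends on the dimethylamino group itself, as against a primary amine, a terminal hydroxy group, a carboxylic acid or a longer chain in its place.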